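The source may report more compounds than this note shows. Statements on the series, on what has been measured and on what is new or still open speak of the compounds shown alone.

In a functional assay on MDA-MB-231 cells (Homo sapiens) for antiproliferative activity, with a stated time of 4 days (a lower number here means a stronger inhibitor, a higher number a weaker inhibitor), compound 1 `CCCCc1ccc2[nH]c(-c3ccc(C(F)(F)F)cc3)c(/C=N/NC(=O)c3ccccc3)c2c1` gives 300 nM and compound 2 `CCCCc1ccc2[nH]c(-c3ccc(C(F)(F)F)cc3)c(/C=N/NC(=O)c3ccc(OC)cc3)c2c1` gives 284 nM; the step between them is a 1.1-fold lower number from compound 1 to compound 2 (0.02 log units; within the scatter). Compound 3 `CCCCc1ccc2[nH]c(-c3ccc(C(F)(F)F)cc3)c(/C=N/NC(=O)c3ccc([N+](=O)[O-])cc3)c2c1`, at 2040 nM, has the highest number of the three. Compound 4 `CCCCc1ccc2[nH]c(-c3ccc(C(F)(F)F)cc3)c(/C=N/NC(=O)c3ccncc3)c2c1` has pyridin-4-yl in place of 4-nitrophenyl on a carbonyl carbon. Among the measured compounds shown here, two measured steps bear on this change: a 6.8-fold higher number from compound 1 to compound 3 (0.83 log units; beyond the scatter) and a 7.2-fold higher number from compound 2 to compound 3 (0.86 log units; beyond the scatter). Both arrive at the 4-nitrophenyl group, which compound 4 no longer carries, so a move back toward compound 1 at 300 nM is expected. For the measured compounds named here, no measured compound has a hetero atom in that ring, so the return may be only partial. The expected change is a 3.4-fold lower number from compound 3 to compound 4 (0.53 log units; beyond the scatter). For compound 4 the estimated value is 600 nM, with an expected range of 220 nM to 1700 nM.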

Compound 4, half-maximal inhibitory concentration: 94 nM
Estimate against measurement, compound 4: 6.4-fold (0.81 log units) above, and the stated range ends above it.
By their numbers in this assay, from the lowest: compound 4; then compounds 2 and 1 (each within the scatter of the next); then compound 3.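

In this assay, the group on this carbonyl carbon can do more than avoid the loss seen with 4-nitrophenyl: pyridin-4-yl beats both phenyl (a 3.2-fold lower number from compound 1 to compound 4 (0.50 log units; beyond the scatter)) and 4-methoxyphenyl (a 3.0-fold lower number from compound 2 to compound 4 (0.48 log units; beyond the scatter)). The swap from 4-nitrophenyl (a 22-fold lower number from compound 3 to compound 4 (1.34 log units; beyond the scatter)) is the largest step among these compounds, so the ring at this position matters more than the first three compounds suggested. Nothing measured here explains this gain. The compounds shown leave open whether the place of the ring nitrogen matters, as pyridin-3-yl and pyridin-2-yl are absent. They also leave open how a pyrimidine ring would behave here.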